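Benzyl to tert-butyl on compound 2

The compounds below may be only part of what the source reports. "The series", "measured", "known", "first", "only" and "open" are said of these compounds alone.

In a functional assay on L1210 cells (Mus musculus) for cytotoxicity (on this read-out higher numbers stand for weaker inhibition and lower numbers for stronger inhibition), compound 1 `COC(=O)[C@@H]1Cc2ccc(OC)c(c2)Oc2ccc(cc2)C[C@H](N(C)C(=O)OCc2ccccc2)C(=O)N1C` gives 0.04 ug/mL and compound 2 `COC(=O)[C@@H]1Cc2ccc(OC)c(c2)Oc2ccc(cc2)C[C@H](N(C)C(=O)OCc2ccccc2)C(=O)N1` gives 0.05 ug/mL. Compound 3 `COc1ccc(C[C@H]2C(=O)N[C@@H](C)C(=O)N(C)CCc3ccc(cc3)Oc3cccc(c3)CCC(=O)NC(C)C(=O)N[C@@H](C)C(=O)N2C)cc1`, a different structure, gives 20 ug/mL, far above both. Compound 2 therefore stands at the low, stronger-inhibition end of the three numbers, level with compound 1 within the scatter.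

Compound 4 `COC(=O)[C@@H]1Cc2ccc(OC)c(c2)Oc2ccc(cc2)C[C@H](N(C)C(=O)OC(C)(C)C)C(=O)N1` keeps the core of compound 2 and changes in one place: tert-butyl in place of benzyl on an oxygen next to a carbonyl group. This puts tert-butyl in place of benzyl on an oxygen next to a carbonyl group. Among the measured compounds shown here, the only measured step is a 1.3-fold higher number from compound 1 to compound 2 (0.10 log units; within the scatter), which lies within the scatter. That step swaps hydrogen for methyl on an amide-type nitrogen in a ring, so it bears on the present change only indirectly. For the measured compounds named here, no measured pair tests the swap of benzyl for tert-butyl. The expected change, loosely estimated, is a modest one towards a higher number: a 2.0-fold higher number from compound 2 to compound 4 (0.30 log units; within the scatter). For compound 4 the estimated value in this assay is 0.1 ug/mL, with an expected range of 0.03 ug/mL to 0.4 ug/mL.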

Compound 4, half-maximal inhibitory concentration: 0.06 ug/mL
Beside the measured number, compound 4's estimate is 1.7-fold (0.22 log units) above it; the range from low to high includes it.
By their numbers in this assay, from the lowest: compounds 1, 2 and 4 (each within the scatter of the next); then compound 3.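

In this assay, among the compounds shown here, the exchange of benzyl for tert-butyl gives a 1.2-fold higher number from compound 2 to compound 4 (0.08 log units; within the scatter) and so lies within the scatter, which is the first reading at this place, on an oxygen next to a carbonyl group; the earlier step concerned only an amide-type nitrogen in a ring. For this pair, the six-membered aromatic ring of the benzyl group can leave, with a smaller group without a ring entering, and the cytotoxicity read-out stays level. Nothing at hand gives a reason for this level result.

The compounds shown leave open whether the number would hold with a free amine in place of the whole benzyloxycarbonyl group, or with a longer chain on that oxygen. They also leave open whether tert-butyl behaves the same way on the core of compound 1.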